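Benzyl sulfone ring: difluoro substitution in the shared core

The compounds below may be only part of what the source reports. "The series", "measured", "known", "first", "only" and "open" are said of these compounds alone.

Compound 1 `CCCS(=O)(=O)c1nnc(COc2cc(C)c3c(C)cc(=O)oc3c2)o1` reaches only the limit > 100000 nM in a functional assay on MCF7 cells (Homo sapiens) for antiproliferative activity, read by MTT assay, with a stated time of 24 h; on this read-out lower numbers stand for stronger inhibition and higher numbers for weaker inhibition. Compound 2 `Cc1cc(OCc2nnc(S(=O)(=O)Cc3ccccc3)o2)cc2oc(=O)cc(C)c12` gives 38600 nM in this assay, the sole number shown. The step of an at least 2.5-fold lower number from compound 1 to compound 2 (0.41 log units; beyond the scatter) rests on (the limit of > 100000 nM in this assay, at which 1 of the 2 values shown sits). Compound 3 `Cc1cc(OCc2nnc(S(=O)(=O)Cc3ccc(F)c(F)c3)o2)cc2oc(=O)cc(C)c12` differs from compound 2 by 3,4-difluorophenyl in place of phenyl on a saturated chain carbon bound to a sulfonyl sulfur. Among the measured compounds shown here, no measured step changes substituents on that phenyl, so no step bears directly on this change; the only step is a different kind. A step within the scatter, or none, is therefore expected: a 1.3-fold lower number from compound 2 to compound 3 (0.11 log units; within the scatter). Compound 3 is expected to give 30000 nM, between 10000 nM and 90000 nM.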

Compound 3, half-maximal inhibitory concentration: 55200 nM
Estimate against measurement, compound 3: 1.8-fold (0.26 log units) below; low and high end bracket the measured number.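

In this assay, the change to 3,4-difluorophenyl gives a 1.4-fold higher number from compound 2 to compound 3 (0.16 log units; within the scatter), so at this place on a saturated chain carbon bound to a sulfonyl sulfur, the two fluorines leave no effect that can be separated from the scatter. The step of an at least 1.8-fold lower number from compound 1 to compound 3 (0.25 log units; that floor lies within the scatter) does not clearly separate its two compounds, and its floor rests on a limit: the limit of > 100000 nM in this assay, at which 1 of the 3 values shown sits.

The compounds shown leave open whether an amine or a carboxylic acid on that phenyl would move the number. They also leave open what a longer chain carrying the phenyl would do.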